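Replacing the Thiophene Ring with a Methyl Group

This account rests on a few compounds, and the source may have more. Where it says the series, first, only, none or still open, it means among the compounds named here.

In a functional assay on TSGH 9201 cells (Homo sapiens) for cytotoxicity (on this read-out lower numbers stand for stronger inhibition and higher numbers for weaker inhibition), compound 2 `COc1ccc(S(=O)(=O)N2CCc3cccc(NC(=O)c4cccs4)c32)cc1` gives 54 nM, the higher of the two numbers recorded in this set. Its nearest neighbour is compound 3 `COc1ccc(S(=O)(=O)N2CCc3cccc(NC(=O)c4ccco4)c32)cc1`, which in this assay gives 11.1 nM, a step of a 4.9-fold lower number from compound 2 to compound 3 (0.69 log units; beyond the scatter) that lies beyond the scatter. Compound 1 `COc1ccc(S(=O)(=O)N2CCc3cccc(NCc4ccccc4)c32)cc1` is recorded only as a limit of the assay, > 10000 nM (the limit of > 10000 nM in this assay, at which 1 of the 3 values shown sits). From compound 1 to the two acyl compounds the steps are large: an at least 180-fold lower number from compound 1 to compound 2 (2.26 log units; beyond the scatter) and an at least 900-fold lower number from compound 1 to compound 3 (2.95 log units; beyond the scatter).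

Compound 4 `COc1ccc(S(=O)(=O)N2CCc3cccc(NC(C)=O)c32)cc1` has not yet been measured. It differs from compound 2 in that (methyl in place of thiophen-2-yl on a carbonyl carbon). Among the compounds with values here, the carbonyl is kept, so the steps from compound 1 do not directly measure this change; the only step at the same place is a 4.9-fold lower number from compound 2 to compound 3 (0.69 log units; beyond the scatter), where exchanging one ring for another already moved the number beyond the scatter. Removing the ring altogether is expected to give a weaker result, a step of a 9.3-fold higher number from compound 2 to compound 4 (0.97 log units; beyond the scatter). Compound 4 is therefore estimated at 500 nM, with a likely range from 100 nM to 5000 nM.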

Compound 4, half-maximal inhibitory concentration: 103 nM
For compound 4 the middle estimate is 4.9-fold (0.69 log units) above the measured one; measured number inside the range.
By their numbers in this assay, from the lowest: compound 3; then compounds 2 and 4 (each within the scatter of the next). At a limit, above all of these: compound 1.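

In this assay, a ring on this carbonyl carbon proves not to be needed for a number in this range, as methyl in place of thiophen-2-yl gives a 1.9-fold higher number from compound 2 to compound 4 (0.28 log units; within the scatter). The furan-2-yl ring does stand apart from methyl, with a 9.3-fold higher number from compound 3 to compound 4 (0.97 log units; beyond the scatter), so among these compounds it is the furan-2-yl ring, and not the mere presence of a ring, that goes with the lowest number. Acetyl on the nitrogen is already enough for an at least 97-fold lower number from compound 1 to compound 4 (1.98 log units; beyond the scatter), a step that rests on compound 1 being recorded only as a limit: the limit of > 10000 nM in this assay, at which 1 of the 4 values shown sits.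

The compounds shown leave open where a longer chain such as propyl, or a phenyl ring, on this carbonyl carbon would fall relative to compound 3 and compound 4. They also leave open what a benzoyl group on the same nitrogen would give, which would set the carbonyl apart from the ring of the benzyl group in compound 1.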